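The source may report more compounds than this note shows. Statements on the series, on what has been measured and on what is new or still open speak of the compounds shown alone.

Measured so far:
compound 1 `CCC[C@@H]1NC(=O)[C@@H](C(C)C)NC(=O)[C@@H](Cc2ccc(O)cc2)NCCCc2ccccc2CCCNC1=O`, > 10000 nM
compound 2 `CCC[C@@H]1NC(=O)[C@@H](C(C)C)NC(=O)[C@@H](Cc2ccc(O)cc2)NCCOc2ccccc2CCCNC1=O`, 55 nM

In an assay on isolated protein for displacement of a labelled ligand from Motilin receptor (Homo sapiens) (a lower number here means a stronger inhibitor, a higher number a weaker inhibitor), compound 1 reaches only a limit, > 10000 nM, and nothing more than that limit is known of it (the limit of > 10000 nM in this assay, at which 1 of the 2 values shown sits). In this assay, among the measured compounds shown here, compound 2 gives 55 nM, the only actual number in the set. Compound 3 `CCC[C@@H]1NC(=O)[C@@H](C(C)C)NC(=O)[C@@H](c2ccccc2)NCCOc2ccccc2CCCNC1=O` is not yet measured. It differs from compound 2 by phenyl in place of 4-hydroxybenzyl on a saturated ring carbon. For the measured compounds named here, with no measured pair of this kind to lean on, the step in this assay is expected to weaken binding by more than the usual scatter: an 11-fold higher number from compound 2 to compound 3 (1.04 log units; beyond the scatter). Compound 3 is therefore expected to give about 600 nM in this assay, with a range from 100 nM to 5000 nM.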

Compound 3, inhibition constant: > 10000 nM
Compound 3 ended at the assay's limit; the forecaster's own chance of this, stated with the estimate: 15%; at least 16-fold (1.22 log units) between middle value and limit.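

In this assay, among the compounds shown here, phenyl in place of 4-hydroxybenzyl on this saturated ring carbon gives an at least 180-fold higher number from compound 2 to compound 3 (2.25 log units; beyond the scatter), the first measured step at this position. Compound 3 gives > 10000 nM, which is a limit of the assay and not a number. Binding in this series therefore depends strongly on the group at this carbon, and this change is not tolerated on the shared core. The step removes both the hydroxyl and the carbon linking the aromatic ring, so their shares remain unresolved. Benzyl would separate the two, and 4-aminobenzyl would test another group in place of the hydroxyl.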